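A Pyrazole Ring in Place of the Acetyl Group

The source may report more compounds than this note shows. Statements on the series, on what has been measured and on what is new or still open speak of the compounds shown alone.

Measured so far, all in an assay on cells for inhibition of MAP kinase-interacting serine/threonine-protein kinase 1 (Homo sapiens), read by mobility shift assay, with stated times of 10 min and 60 min, in the presence of a further agent that is not named here; a lower number here means a stronger inhibitor, a higher number a weaker inhibitor:
compound 1, `NC(=O)c1ccc(-c2cccnc2)cc1OC1CCNCC1`, gives 1100 nM
compound 2, `CC(=O)c1cncc(-c2ccc(C(N)=O)cc2)c1`, gives 8000 nM
compound 3, `CNC(=O)c1cncc(-c2ccc(C(N)=O)c(OC(C)C)c2)c1`, gives 1900 nM

Among these three, compound 2 stands at the highest number and is therefore the weakest inhibitor. Its nearest neighbour is compound 3, whose lower number lies beyond the scatter; the furthest is compound 1, again with a gap beyond the scatter. Compound 2 is the only one of the three that carries an acetyl group on its pyridine-type ring, and the only one lacking any substituent on the benzamide ring.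

The next compound, compound 4, `Cn1cc(-c2cncc(-c3ccc(C(N)=O)cc3)c2)cn1`, keeps the benzamide and the shared core of compound 2 and changes a single place: 1-methyl-1H-pyrazol-4-yl in place of acetyl on an aromatic carbon. The aromatic five-membered ring with two nitrogen atoms replaces a small non-aromatic group, and the count of hydrogen-bond acceptors rises.

For the measured compounds named here, no measured pair shows this exact exchange, so the expectation rests on compound 2 alone and on the general level of compounds 1 and 3. The step from compound 2 to compound 4 in this assay is expected to be a 3.2-fold lower number from compound 2 to compound 4 (0.51 log units; beyond the scatter), toward a stronger inhibitor, beyond the scatter. Compound 4 is therefore estimated at 2500 nM, with a range from 600 nM to 10000 nM.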

Compound 4, half-maximal inhibitory concentration: 800 nM
Compound 4: the middle estimate sits 3.1-fold (0.49 log units) above what was measured, and the stated range covers the measured number.
By their numbers in this assay, from the lowest: compounds 4, 1 and 3 (each within the scatter of the next, the first and the last beyond it); then compound 2.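

In this assay, the exchange of acetyl for 1-methyl-1H-pyrazol-4-yl on this aromatic carbon, two atoms from the ring nitrogen, gives a 10-fold lower number from compound 2 to compound 4 (1.00 log units; beyond the scatter) and so lies beyond the usual scatter. For the compounds shown here, the three earlier compounds offered no pair differing at this place, so this is the first direct reading of the position, and it shows that the number moves with the group placed there while the benzamide ring stays free of any substituent. It also shows that acetyl, with its 3 heavy atoms and no ring, can give way to a group of 6 heavy atoms with a five-membered aromatic ring without any loss in this assay, though nothing at hand explains the gain.

A single pair cannot separate the part played by the aromatic ring from that of its two nitrogen atoms or its methyl group, and a pyrazole without the methyl, a phenyl ring or a morpholine at the same carbon would bear on that question. On these data alone, it also remains open whether the same exchange would hold on a benzamide ring carrying an isopropoxy group.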